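The source may hold more compounds than are shown below. What is called first, only, known or untested is meant among the compounds shown, and "the series" means these compounds.

In a functional assay on HCT-116 cells (Homo sapiens) for inhibition, read by MTT assay, with a stated time of 48 h (on this read-out lower numbers stand for stronger inhibition and higher numbers for weaker inhibition), three compounds have been measured. Compound 1 `C[Se]c1ccc(N(C)c2nc(C3CC3)nc3ccccc23)cc1` gives 15 nM and compound 3 `Cc1nc(N(C)c2ccc([Se]C#N)c(C)c2)c2ccccc2n1` gives 13 nM, two values within the scatter of each other. Compound 2 `COc1ccc(N(C)c2nc(C)nc3ccccc23)cc1OCCCCCC[Se]C#N` gives 6180 nM, the highest number of the three, and its distance from each of the others lies beyond the scatter. Compound 4 `COc1ccc(N(C)c2nc(C)nc3ccccc23)cc1[Se]C` has not yet been measured. It differs from compound 2 at one place, on an aromatic carbon, ortho to a methoxy group and meta to a large group: a group of 2 heavy atoms (1 carbon, 1 selenium; no ring) in place of a group of 10 heavy atoms (7 carbon, 1 nitrogen, 1 oxygen, 1 selenium; no ring), on an aromatic carbon. Going by the values given here, no measured pair isolates this change, so the step in this assay can only be judged from the three values. The short selenium-bearing group of compound 1 at 15 nM and that of compound 3 at 13 nM accompany far lower numbers than compound 2 shows, although three compounds establish no firm pattern. A large step toward stronger inhibition, well beyond the scatter, is therefore expected. The expected change is a 150-fold lower number from compound 2 to compound 4 (2.19 log units; beyond the scatter). For compound 4 the estimated value is 40 nM, with an expected range of 8 nM to 300 nM.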

Compound 4, half-maximal inhibitory concentration: 28 nM
For compound 4 the middle estimate is 1.4-fold (0.15 log units) above the measured one, and the stated range covers the measured number.
By their numbers in this assay, from the lowest: compounds 3, 1 and 4 (each within the scatter of the next, the first and the last beyond it); then compound 2.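

In this assay, going by these compounds alone, the step of a 220-fold lower number from compound 2 to compound 4 (2.34 log units; beyond the scatter) gives the only direct reading of this position, an aromatic carbon ortho to a methoxy group and meta to a large group. It shows that the number at this carbon depends strongly on the group it carries, with the group of 2 heavy atoms (1 carbon, 1 selenium; no ring) going with far stronger inhibition than the group of 10 heavy atoms. Nothing measured here explains the size of this step.

The change replaces the whole group at once, so it does not separate the contributions of the oxygen, the chain and the nitrile. Going by these compounds, whether a shorter chain ending in the same nitrile, or an amine or a carboxylic acid on this carbon, would keep the number of compound 4 remains open.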